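Hydroxy to amino on the amide chain: second core

The compounds below may be only part of what the source reports. "The series", "measured", "known", "first", "only" and "open" are said of these compounds alone.

Two cores carry the same side chain. Compound 1 `COc1ccc(C(=O)c2ccc3c(c2)C=CC(C)(C)O3)c(NC(=O)CO)c1` and compound 3 `C=C(c1ccc(OC)cc1NC(=O)CO)c1ccc(OC)c2c1OC(C)(C)C=C2` each bear a ((hydroxymethyl)carbonyl)amino group; the difference between the two cores is not broken down here. In a functional assay on HeLa cells (Homo sapiens) for antiproliferative activity, read by MTT assay, with a stated time of 48 h (on this read-out lower numbers stand for stronger inhibition and higher numbers for weaker inhibition), compound 1 gives 240 nM, and compound 3 gives 40 nM, the lowest number among the three measured compounds, with its steps to both others beyond the scatter.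

Compound 2 `COc1ccc(C(=O)c2ccc3c(c2)C=CC(C)(C)O3)c(NC(=O)CN)c1` keeps the core of compound 1 and differs from it by amino in place of hydroxy on a saturated chain carbon bound to a carbonyl carbon. In this assay compound 2 gives 580 nM. Among the compounds with values here, the step of a 2.4-fold higher number from compound 1 to compound 2 (0.38 log units; beyond the scatter) is the only measured instance of this change.

Compound 4 `C=C(c1ccc(OC)cc1NC(=O)CN)c1ccc(OC)c2c1OC(C)(C)C=C2` applies the same change to the core of compound 3: amino in place of hydroxy on a saturated chain carbon bound to a carbonyl carbon. The place is described in the same words for both pairs, so this is counted as the same change. Within the data shown here, whether its size carries over from one core to the other cannot be checked here, since only one pair has been measured; the expectation rests on that pair alone.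

Among the measured compounds shown here, the expectation for compound 4 in this assay takes its direction and size from the measured step, because a 2.4-fold higher number from compound 1 to compound 2 (0.38 log units; beyond the scatter) is the single precedent. Compound 4 is therefore expected to show a step of a 2.5-fold higher number from compound 3 to compound 4 (0.40 log units; beyond the scatter). The estimate for compound 4 in this assay is 100 nM, with a likely range from 50 nM to 200 nM.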

Compound 4, half-maximal inhibitory concentration: 120 nM
For compound 4 the middle estimate is 1.2-fold (0.08 log units) below the measured one; measured number inside the range.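

In this assay, the new pair gives a 3.0-fold higher number from compound 3 to compound 4 (0.48 log units; beyond the scatter), and the change of hydroxy to amino on a saturated chain carbon bound to a carbonyl carbon therefore has a matching effect on the read-out on both cores: the same change on two cores in this assay, a 2.4-fold higher number (0.38 log units; beyond the scatter) from compound 1 to compound 2 and a 3.0-fold higher number (0.48 log units; beyond the scatter) from compound 3 to compound 4, 1.2-fold (0.09 log units) apart, within the scatter of two such steps Within this series, then, the earlier step on the core of compound 1 served as a fair guide to the step on the core of compound 3, with the number rising in both pairs and no measurable difference in size between them. Within the data shown here, this rests on only two pairs and shows that the change carried over between these two cores, but it does not show that it would carry over to any further core, and it gives no account of why amino gives the higher number in both.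

The compounds shown compare only hydroxy and amino at this place, so it remains open how a dimethylamine, a carboxylic acid or a longer chain such as 2-hydroxyethyl or 2-aminoethyl would behave there. As far as these compounds go, it also remains open whether any such replacement would give the same step on both cores, as the change from hydroxy to amino does here.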